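A Carboxy Group Enters at the Carbonyl Carbon

The source may report more compounds than this note shows. Statements on the series, on what has been measured and on what is new or still open speak of the compounds shown alone.

Within the data shown here, in a functional assay on MCF7 cells (Homo sapiens) for antiproliferative activity, read by MTT assay, with a stated time of 48 h (a higher number here means a weaker inhibitor, a lower number a stronger inhibitor), compound 2 `CCOC(=O)CN(C)C(=O)c1ccc(C(CC)(CC)c2ccc(OCCC(O)(CC)CC)c(C)c2)n1CC` gives 3210 nM, the only true number so far. Compound 1 `CCC(C)C(NC(=O)c1ccc(C(CC)(CC)c2ccc(OCCC(O)(CC)CC)c(C)c2)n1CC)C(=O)OC` gives > 50000 nM, which is a limit of the assay and not a number.

Compound 3 `CCC(C)C(NC(=O)c1ccc(C(CC)(CC)c2ccc(OCCC(O)(CC)CC)c(C)c2)n1CC)C(=O)O` has not yet been measured. Its structure differs from that of compound 2 in one place: (1-carboxy-2-methylbutyl)amino in place of ((ethoxycarbonyl)methyl)(methyl)amino on a carbonyl carbon. The new group, (1-carboxy-2-methylbutyl)amino, sits on a carbonyl carbon whose other neighbour is an aromatic carbon.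

Among the measured compounds shown here, only one measured step bears on this change. It also replaced the group on a carbonyl carbon and gave an at least 15-fold lower number from compound 1 to compound 2 (1.19 log units; beyond the scatter), a large step beyond the scatter. So a swap at this place can shift the result strongly in this assay, although a single step cannot fix the direction for a new group. For the measured compounds named here, with only that step as a guide, a weaker result is expected, meaning a higher number. The expected change is a 4.7-fold higher number from compound 2 to compound 3 (0.67 log units; beyond the scatter), and it is a moderate one held with wide uncertainty. Compound 3 is estimated at 15000 nM, with an expected range from 3000 nM to 50000 nM.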

Compound 3, half-maximal inhibitory concentration: 11300 nM
For compound 3 the middle estimate is 1.3-fold (0.12 log units) above the measured one, within the range that was stated.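

Among these compounds, two true numbers now stand at this carbonyl carbon, so direction can be read here for the first time: (1-carboxy-2-methylbutyl)amino in place of ((ethoxycarbonyl)methyl)(methyl)amino gives a 3.5-fold higher number from compound 2 to compound 3 (0.55 log units; beyond the scatter). The far end of the group matters too, as hydrogen in place of methyl on an oxygen next to a carbonyl group gives an at least 4.4-fold lower number from compound 1 to compound 3 (0.64 log units; beyond the scatter), showing that a small edit within this group can change the result beyond the scatter. That second step can be given only as a minimum because compound 1 stands at a limit of the assay and not at a true number: the limit of > 50000 nM in this assay, at which 1 of the 3 values shown sits.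

Going by these compounds, what stays open is which part of the swap between compound 2 and compound 3 carries the change, whether the carboxy group, the branched 2-methylbutyl chain or the methyl on the amide nitrogen. A (carboxymethyl)(methyl)amino group would pair the carboxylic acid with the unbranched frame of compound 2 and help separate these parts, while a basic amine or a longer chain on this carbonyl carbon would show how far the position reaches.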